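Furan in place of pyrrole on the aryl ether

The compounds below may be only part of what the source reports. "The series", "measured", "known", "first", "only" and "open" are said of these compounds alone.

Compound 1 `Cc1ccnc(-c2ccccc2OCC2=NCCN2)c1`: < 100000 nM (a limit)
Compound 2 `c1c[nH]c(-c2ccccc2OCC2=NCCN2)c1`: 1.26 nM

Among the compounds with values here, in a functional assay for activation of Alpha-1A adrenergic receptor (Homo sapiens), read by calcium flux (a higher number here means that more compound is needed for the effect, a lower number that less compound is needed), compound 2 gives 1.26 nM, the only plain number among the two results. Compound 1 in this assay gives only a limit, < 100000 nM (the limit of < 100000 nM in this assay, at which 1 of the 2 values shown sits). Compound 3 `Cc1ccoc1-c1ccccc1OCC1=NCCN1` differs from compound 2 by 3-methylfuran-2-yl in place of 1H-pyrrol-2-yl on an aromatic carbon. Within the data shown here, no measured pair differing in one place exists here, so the size of this step rests on expectation alone: compound 3 is expected to need more compound than compound 2, by a step of a 48-fold higher number from compound 2 to compound 3 (1.68 log units; beyond the scatter) that lies beyond the usual scatter. Compound 3 is accordingly estimated at 60 nM, within a range from 5 nM to 800 nM.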

Compound 3, half-maximal effective concentration: 3.16 nM
For compound 3 the middle estimate is 19-fold (1.28 log units) above the measured one; measured number below the stated range.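

In this assay the exchange gives a 2.5-fold higher number from compound 2 to compound 3 (0.40 log units; beyond the scatter) and so counts as a modest step, showing that this place on the six-membered aromatic ring of carbon only can hold a 3-methylfuran-2-yl group as well as a 1H-pyrrol-2-yl group. The group in compound 3 carries no hydrogen-bond donor, yet the step stays modest. Nothing shown here gives a cause for this step.

From the compounds shown here alone, the furan ring and its methyl group enter together, so the share of each in the step stays open. Going by these compounds, how an unsubstituted furan-2-yl or a thiophen-2-yl group would fare at this place also remains open.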